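The source may hold more compounds than are shown below. What is called first, only, known or untested is meant among the compounds shown, and "the series" means these compounds.

Three compounds sharing one core, each carrying a different group on a saturated chain carbon bound to a sulfonamide nitrogen, have been measured in an assay on isolated protein for inhibition of bone morphogenetic protein 1 (Homo sapiens); a lower number here means a stronger inhibitor, a higher number a weaker inhibitor. Compound 1, `COc1ccc(S(=O)(=O)N(Cc2cc(F)cc(F)c2)[C@H](C)C(=O)NO)cc1`, gives 140 nM in this assay. Compound 2, `COc1ccc(S(=O)(=O)N(Cc2cc(C(F)(F)F)cc(C(F)(F)F)c2)[C@H](C)C(=O)NO)cc1`, gives 220 nM in this assay, a number within the scatter of compound 1, so no order can be read between these two. Compound 3, `COc1ccc(S(=O)(=O)N(Cc2ccc(Cl)c([N+](=O)[O-])c2)[C@H](C)C(=O)NO)cc1`, gives 30 nM in this assay, which lies beyond the scatter and lower than compound 1. Among the three numbers, compound 1 therefore holds the second highest place, with compound 2 nearest and compound 3 furthest away.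

Compound 4, `COc1ccc(S(=O)(=O)N(Cc2ccc(F)c(F)c2)[C@H](C)C(=O)NO)cc1`, has not yet been measured in this assay. It differs from compound 1 in one place: 3,4-difluorophenyl in place of 3,5-difluorophenyl on a saturated chain carbon bound to a sulfonamide nitrogen. Among the measured compounds shown here, no measured pair in this set shows that change, so its size is unknown from the data. The two groups have the same atoms, joined differently. The step of a 1.1-fold lower number from compound 1 to compound 4 (0.03 log units; within the scatter) is expected to be small, probably within the scatter, with no clear direction. On this basis compound 4 is estimated at 130 nM in this assay, with a range from 50 nM to 350 nM.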

Compound 4, half-maximal inhibitory concentration: 76 nM
Compound 4: the middle estimate sits 1.7-fold (0.23 log units) above what was measured; the measured number falls inside the stated range.
By their numbers in this assay, from the lowest: compound 3; then compounds 4, 1 and 2 (each within the scatter of the next, the first and the last beyond it).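

Among the compounds shown here, compound 1 and compound 4 form the first pair in this set that differs in one place only, so the position can now be read directly rather than through compounds that differ in their whole substitution. In this assay, 3,4-difluorophenyl in place of 3,5-difluorophenyl on a saturated chain carbon bound to a sulfonamide nitrogen gives a 1.8-fold lower number from compound 1 to compound 4 (0.27 log units; within the scatter), which shows that this rearrangement of the same atoms does not separate the two compounds at this place. Nothing available here explains how either difluorophenyl group acts in this assay.

The compounds shown leave open how a plain benzyl or a benzyl carrying a single fluorine would read at this place, and whether a carboxylic acid or an amine on that ring would give a step beyond the scatter from compound 1. They also leave open whether the same swap of difluorophenyl groups would remain this small on a core with an ethoxy group in place of the methoxy group.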